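The source may report more compounds than this note shows. Statements on the series, on what has been measured and on what is new or still open speak of the compounds shown alone.

Measured compounds:
- compound 1, `COc1ccc(C(=O)NC2CCCC2)cc1-c1[nH]nc2nc(Nc3ccc(F)cc3F)ccc12`: in a functional assay on the whole organism (strain Wistar) for inhibition, with Rattus norvegicus as the target, at a dose of 25 mg/kg by the oral route (on this read-out lower numbers stand for less inhibition and higher numbers for more inhibition at the one dose given (going by the name of the read-out)), compound 1 gives 34%
- compound 2, `COc1ccc(C#CC(C)(C)O)cc1-c1[nH]nc2nc(Nc3ccc(F)cc3F)ncc12`: in this assay compound 2 gives 34%

Compound 2 stands level with compound 1 at the digits shown; the two values lie within the scatter, so no order between them is claimed. For the measured compounds named here, no step between measured compounds is available to calibrate the change to compound 3.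

Compound 3, `COc1ccc(CCC(C)(C)O)cc1-c1[nH]nc2nc(Nc3ccc(F)cc3F)ncc12`, is not yet measured. It differs from compound 2 in one place: 3-hydroxy-3-methylbutyl in place of 3-hydroxy-3-methylbut-1-yn-1-yl on an aromatic carbon. With no measured step of this kind in hand, the change is expected to stay within the scatter or fall slightly. The estimated step of a number 4 percentage points lower from compound 2 to compound 3 (within the scatter) is small. For compound 3 in this assay the expected value is 30%, with a range from 15% to 48%.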

Compound 3, a percentage reported as inhibition, in the whole organism at one dose (the size of the read-out at that dose, not a potency): 36%
Estimate against measurement, compound 3: 6 percentage points below, within the range that was stated.
By their numbers in this assay, from the lowest: compounds 1, 2 and 3 (each within the scatter of the next).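

For the compounds shown here, replacing 3-hydroxy-3-methylbut-1-yn-1-yl with 3-hydroxy-3-methylbutyl on the aromatic carbon para to a methoxy group gives a number 2 percentage points higher from compound 2 to compound 3 (within the scatter) in this assay, so this single change can be read for the first time. At this position, at the one dose given, the read-out holds with or without the triple bond of the chain. Nothing available bears on why the two chains read alike.

As far as these compounds go, whether a carboxylic acid or a primary amine in place of the hydroxy group would hold the read-out remains open. So does the effect of a longer chain at this position.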